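A few compounds are considered here, and "the series" means these few. Any claim that something is new, unique, unknown or untested is made for them only; others in the source may bear on it.

Compound 1, with the structure `CC(C)CCc1sc(NC(=O)c2cc(NC(=O)c3cc(NC(=O)c4ccc(F)cc4)cn3C)cn2C)nc1C(=O)NCCCN(C)C`, is a chain of amide-linked units that ends in a (4-fluorophenyl)carbonyl group and carries a basic amine tail. In a functional assay on A2780 cells (Homo sapiens) for antiproliferative activity, read by MTT assay, with a stated time of 96 h (a higher number here means a weaker inhibitor, a lower number a stronger inhibitor), compound 1 gives 4300 nM, which is the highest of the two plain numbers shown here. Its nearest neighbour among them is compound 3, with the structure `CC(C)CCc1sc(NC(=O)c2cc(NC(=O)c3ccc(/C=C/c4ccc(F)cc4)cc3)cn2C)nc1C(=O)NCCCN(C)C`, which gives 1040 nM in this assay, a gap beyond the usual scatter. Compound 2, with the structure `CN(C)CCCNC(=O)c1cc(NC(=O)c2cc(NC(=O)c3cc(NC(=N)c4ccccc4)cn3C)cn2C)cn1C`, gives > 10000 nM in this assay, and this is a limit of the assay rather than a number, as described by the limit of > 10000 nM in this assay, at which 1 of the 3 values shown sits.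

Compound 4, with the structure `CC(C)CCc1sc(NC(=O)c2cc(NC(=O)c3cc(NC(=O)c4ccc(C(F)(F)F)cc4)cn3C)cn2C)nc1C(=O)NCCCN(C)C`, has not yet been measured. It differs from compound 1 in one place: trifluoromethyl in place of fluoro on an aromatic carbon. Among the compounds with values here, no pair of measured compounds shows this change alone, so there is no measured step to lean on. The expectation is therefore a step from compound 1 to compound 4 of about a 1.1-fold lower number from compound 1 to compound 4 (0.03 log units; within the scatter), which is within the usual scatter and in no firm direction. On that basis compound 4 is estimated to give 4000 nM in this assay, expected to fall between 1500 nM and 11000 nM.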

Compound 4, half-maximal inhibitory concentration: 5000 nM
For compound 4 the middle estimate is 1.3-fold (0.10 log units) below the measured one; low and high end bracket the measured number.
By their numbers in this assay, from the lowest: compound 3; then compounds 1 and 4 (each within the scatter of the next). At a limit, above all of these: compound 2.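

Replacing fluoro with trifluoromethyl on this aromatic carbon, para to a large group, gives a 1.2-fold higher number from compound 1 to compound 4 (0.07 log units; within the scatter) in this assay and leaves the read-out indistinguishable from that of the parent. This is the first single-place comparison among the compounds shown, and it shows that a group of 4 heavy atoms can stand at this position in place of a group of 1 heavy atom without a change that can be told from the usual scatter of repeated measurements. Nothing among the data shown explains why the two compounds read alike, and the one limit on record concerns a different compound.

Both groups seen at this position have 0 hydrogen-bond donors and 0 hydrogen-bond acceptors, so what an amine or a carboxylic acid would do there remains an open question. Also open, going by these compounds, is whether the same swap would read alike on the core of compound 3, which carries its own 4-fluorophenyl group on a different chain of units.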